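The source may hold more compounds than are shown below. What is called first, only, known or untested is meant among the compounds shown, and "the series" means these compounds.

In a functional assay on MOLT-4 cells (Homo sapiens) for inhibition, read by MTT assay, with a stated time of 48 h (a lower number here means a stronger inhibitor, a higher number a weaker inhibitor), the record for this small family of compounds is thin. Compound 1 `CCOC(=O)C(=O)CC(=O)/C=C/c1cn(CCC(C)C)c2ccccc12` has the entry "not determined" (no result reported). Compound 2 `CCOC(=O)C(=O)CC(=O)/C=C/c1cn(Cc2ccc(OC)cc2)c2ccccc12` has the entry "not determined" (no result reported). Going by the values given here, compound 3 `CC(C)CCn1cc(/C=C/C(=O)CC(=O)C(=O)O)c2ccccc21` gives 20000 nM, which is the only actual number so far, so it cannot yet be ranked against anything.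

The next molecule to be tested is compound 4 `O=C(/C=C/c1cn(Cc2ccc(Cl)cc2)c2ccccc12)CC(=O)C(=O)O`, which differs from compound 3 in one place: 4-chlorophenyl in place of isobutyl on a saturated chain carbon bound to an aromatic nitrogen. In words, 4-chlorophenyl stands in place of isobutyl on a saturated chain carbon bound to an aromatic nitrogen. Cut one bond further out, this is isopentyl to 4-chlorobenzyl.

Among the compounds with values here, no measured pair in this family shows what a change of this kind does, so the expectation is only a cautious one: a modest move toward stronger inhibition, which may not exceed the usual scatter of repeated measurements. The estimate amounts to an expected step of a 1.7-fold lower number from compound 3 to compound 4 (0.22 log units; within the scatter). For compound 4 the estimated value is 12000 nM, with an expected range of 4000 nM to 35000 nM.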

Compound 4, half-maximal inhibitory concentration: 19000 nM
Beside the measured number, compound 4's estimate is 1.6-fold (0.20 log units) below it; measured number inside the range.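

The new result shows that this place on the shared core, a saturated chain carbon bound to an aromatic nitrogen, can carry a group with an aromatic ring as well as an open chain. In this assay, swapping isopentyl for 4-chlorobenzyl gives a 1.1-fold lower number from compound 3 to compound 4 (0.02 log units; within the scatter), so the two compounds cannot be told apart, and the larger group brings neither a gain nor a loss in this single pair. Nothing measured here explains why the two groups read alike.

From the compounds shown here alone, it remains open whether a plain benzyl without chlorine, or a longer chain ending in an amine, would shift the number at this place. Steps involving the ethyl esters, compound 1 and compound 2, cannot be read, so what the ester contributes compared with the free acid also stays unknown.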